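The source may hold more compounds than are shown below. What is called first, only, known or untested is meant among the compounds shown, and "the series" means these compounds.

Measured so far:
compound 1, `CC(C)(C)NC(=O)c1ccc(Oc2ccc(CC(=O)O)cc2Cl)c(NS(=O)(=O)c2ccc(Cl)cc2Cl)c1`, 5 nM
compound 2, `CCCCNC(=O)c1ccc(Oc2ccc(CC(=O)O)cc2F)c(NS(=O)(=O)c2ccc(Cl)cc2Cl)c1`, 7 nM

Both compounds were tested in an assay on HEK293 cells for displacement of a labelled ligand from prostaglandin D2 receptor 2 (Homo sapiens), read by scintillation counting, in the presence of a further agent that is not named here; a lower number here means a stronger inhibitor, a higher number a weaker inhibitor. Compound 1 gives 5 nM, and compound 2 gives 7 nM. These two numbers lie within the usual scatter of repeated measurements of each other, so neither compound can be called the stronger inhibitor; compound 1 simply has the lower of the two numbers.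

Compound 3, `O=C(O)Cc1ccc(Oc2ccc(C(=O)NC3CCC3)cc2NS(=O)(=O)c2ccc(Cl)cc2Cl)c(Cl)c1`, has not yet been measured. It differs from compound 1 in one place: cyclobutyl in place of tert-butyl on an amide-type nitrogen. The group that leaves and the group that enters have the same count of heavy atoms, all carbon, neither carries a hydrogen-bond donor or acceptor, and neither bears a charge; the only counted difference is that the entering group closes into a four-membered ring. For the measured compounds named here, no pair of measured compounds shows a step of this kind, so nothing here tells how large a change to expect. Without such a precedent the expectation is no step beyond the scatter in this assay, in either direction. The expected step is no change at the digits printed from compound 1 to compound 3 (within the scatter). For compound 3 the estimate is 5 nM, with a range from 2 nM to 12 nM.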

Compound 3, half-maximal inhibitory concentration: 5 nM
Beside the measured number, compound 3's estimate shows no gap at the digits printed; low and high end bracket the measured number.
By their numbers in this assay, from the lowest: compounds 1, 3 and 2 (each within the scatter of the next).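

In this assay, for the compounds shown here, cyclobutyl in place of tert-butyl on the amide-type nitrogen gives no change at the digits printed from compound 1 to compound 3 (within the scatter) and is the first change that can be read at a single place in the molecule. Compound 2 could not show this, since it differs from compound 1 in two places. At this nitrogen, then, a group with no ring and a group with a four-membered carbon ring, each with the same count of carbon atoms, give numbers that cannot be told apart, and no measurement shown here explains why the two read alike.

This single pair does not show how far that freedom extends, since both groups are made of carbon only and neither carries a hydrogen-bond donor or acceptor. A chain ending in an amine, a chain ending in a carboxylic acid, or a morpholine ring on the same nitrogen, with the rest of compound 1 unchanged, would test whether this place accepts groups of a different kind.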